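This account rests on a few compounds, and the source may have more. Where it says the series, first, only, none or still open, it means among the compounds named here.

Compound 1 `O=C1NC(O)(CCn2cc(C3=CCCCC3)nn2)C(OCc2ccccc2)=C1OCc1ccccc1` was run in an ADME assay on HEK293 cells (Homo sapiens) for cytotoxicity, read by MTT assay, with a stated time of 24 h (a higher number here means a weaker inhibitor, a lower number a stronger inhibitor), and gives 70000 nM. Compound 3 `COC1=C(OC)C(O)(CCn2cc(-c3ccccc3)nn2)NC1=O` gives 62000 nM in this assay; this number and the number of compound 1 lie within the scatter of one another, so the two cannot be ordered. Compound 2 `Cc1ccc(-c2cn(C/C=C3\OC(=O)C(OCc4ccccc4)=C3OCc3ccccc3)nn2)cc1` returns only a limit of the assay in this assay, namely > 100000 nM, which is the limit of > 100000 nM in this assay, at which 1 of the 3 values shown sits. Within the data shown here, no pair of measured compounds differing in a single place is available, so no measured step can be stated.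

Compound 4 `Cc1ccc(-c2cn(CCC3(O)NC(=O)C(OCc4ccccc4)=C3OCc3ccccc3)nn2)cc1` is not yet measured. It differs from compound 1 by 4-methylphenyl in place of cyclohex-1-en-1-yl on an aromatic carbon. Compound 2 also carries a 4-methylphenyl group on its triazole, on a different core, and its reading is a limit. All numbers in the series sit at weak inhibition. The step from compound 1 to compound 4 is expected to be a 1.1-fold higher number from compound 1 to compound 4 (0.06 log units; within the scatter), that is, no change beyond the scatter in either direction. Compound 4 is therefore estimated at 80000 nM, with a range from 40000 nM to 160000 nM.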

Compound 4, half-maximal inhibitory concentration: 45000 nM
For compound 4 the middle estimate is 1.8-fold (0.25 log units) above the measured one; the measured number falls inside the stated range.
By their numbers in this assay, from the lowest: compounds 4, 3 and 1 (each within the scatter of the next). At a limit, above all of these: compound 2.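

In this assay, among these compounds, the swap of cyclohex-1-en-1-yl for 4-methylphenyl on the aromatic carbon of the five-membered aromatic ring with 3 nitrogen gives a 1.6-fold lower number from compound 1 to compound 4 (0.19 log units; within the scatter) and is the first measured step at this position. On the core of compound 1, a non-aromatic carbon ring and a methyl-bearing aromatic one therefore cannot be told apart here, and both sit at weak inhibition. Compound 2 carries the same 4-methylphenyl group on another core and gives only a limit of the assay: the limit of > 100000 nM in this assay, at which 1 of the 4 values shown sits.

On these data alone, whether an amine, a carboxylic acid or a longer alkyl chain at this position would move the number beyond the scatter remains open. No measured finding bears on the cause of this step.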